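Swapping the Amide Group of Compound 1

The source may hold more compounds than are shown below. What is called first, only, known or untested is meant among the compounds shown, and "the series" means these compounds.

In a toxicity assay (LMTK cells) for cytotoxicity, with Mus musculus as the target, read by MTT assay, with a stated time of 72 h (a lower number here means a stronger inhibitor, a higher number a weaker inhibitor), compound 1 (`Cc1c(C)c2c(c(C)c1OC(=O)CCC(=O)O)CCC(C)(C(=O)NCC1CC(C)(C)N([O])C1(C)C)O2`) gives > 300000 nM as a limit of the assay and not as a number. Compound 1 therefore stands at the limit of > 300000 nM in this assay, at which 1 of the 2 values shown sits, in these data. Compound 2 (`Cc1c(C)c2c(c(C)c1O)CCC(C)(C(=O)NCC1CC(C)(C)N([O])C1(C)C)O2`) gives 300000 nM in this assay and carries a hydrogen in place of (2-carboxyethyl)carbonyl on an oxygen on an aromatic ring.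

Within the data shown here, that change gives the only measured step, a number no higher from compound 1 to compound 2 (the limit leaves the size open) and its size stays unknown. It also lies at a different place from the change now in question. Compound 3 (`Cc1c(C)c2c(c(C)c1OC(=O)CCC(=O)O)CCC(C)(C(=O)NC1CC(C)(C)N([O])C1(C)C)O2`) keeps the (2-carboxyethyl)carbonyl group of compound 1, and the change is confined to an amide-type nitrogen, where a group of 10 heavy atoms (8 carbon, 1 nitrogen, 1 oxygen; one five-membered non-aromatic ring with 1 hetero atom) in place of a group of 11 heavy atoms (9 carbon, 1 nitrogen, 1 oxygen; one five-membered non-aromatic ring with 1 hetero atom), on an amide-type nitrogen applies.

Among the measured compounds shown here, no measured step covers this exchange, so the expectation rests on compound 2, whose 300000 nM is the only number available. In this assay the estimated change is a number no higher from compound 1 to compound 3 (the limit leaves the size open) and no size beyond the scatter is expected. Compound 3 is estimated at 300000 nM with an expected range from 100000 nM to 600000 nM and a limit rather than a number may well be expected.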

Compound 3, half-maximal inhibitory concentration: > 300000 nM
Compound 3: no number, only a limit (the forecaster's own chance of this, stated with the estimate: 60%); the middle value sits exactly at the limit.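

In this assay compound 3 gives > 300000 nM, a limit of the assay and not a number. Among these compounds, compound 1 also gives only a limit, so no step between compound 1 and compound 3 can be read. The compounds shown leave open whether exchanging the amide-nitrogen groups changes the result in this assay at all.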